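Varying the aryl group at the hydrazone carbon in the shared core

The compounds below may be only part of what the source reports. "The series", "measured", "known", "first", "only" and "open" are said of these compounds alone.

Measured compounds:
compound 1 `CN(C)CCn1cnnc1-c1cc(Oc2ccc(NC(=O)N/N=C/c3ccc(F)cc3Cl)cc2F)ccn1`: 870 nM
compound 2 `CN(C)CCn1cnnc1-c1cc(Oc2ccc(NC(=O)N/N=C/c3ccc(O)c(F)c3)cc2F)ccn1`: 1970 nM
compound 3 `CN(C)CCn1cnnc1-c1cc(Oc2ccc(NC(=O)N/N=C/c3ccccc3O[N+](=O)[O-])cc2F)ccn1`: 1020 nM

All three were tested in a functional assay on MKN-45 cells (Homo sapiens) for cytotoxicity, read by MTT assay, with a stated time of 72 h; a lower number here means a stronger inhibitor, a higher number a weaker inhibitor. Compound 3 sits second highest of the three numbers; its value is within the scatter of compound 1 and of compound 2, so no ranking among them can be stated. Compound 4 `COc1cc(/C=N/NC(=O)Nc2ccc(Oc3ccnc(-c4nncn4CCN(C)C)c3)c(F)c2)ccc1O` is not yet measured. It differs from compound 3 in one place: 4-hydroxy-3-methoxyphenyl in place of 2-(nitrooxy)phenyl on a carbon with a double bond to nitrogen. The nearest guide is compound 2, which also carries a phenol on this carbon: the step of a 2.3-fold higher number from compound 1 to compound 2 (0.35 log units; beyond the scatter) was modest, while a 1.9-fold lower number from compound 2 to compound 3 (0.29 log units; within the scatter) stayed within the scatter. A small rise in the number for compound 4 is expected, a 1.7-fold higher number from compound 3 to compound 4 (0.22 log units; within the scatter). The estimate for compound 4 is 1700 nM, with a range from 800 nM to 3800 nM.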

Compound 4, half-maximal inhibitory concentration: 3780 nM
Estimate against measurement, compound 4: 2.2-fold (0.35 log units) below; the measured number falls inside the stated range.
By their numbers in this assay, from the lowest: compounds 1, 3, 2 and 4 (each within the scatter of the next, the first and the last beyond it).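

At the carbon with a double bond to nitrogen, 4-hydroxy-3-methoxyphenyl in place of 2-(nitrooxy)phenyl gives a 3.7-fold higher number from compound 3 to compound 4 (0.57 log units; beyond the scatter) and so moves the number beyond the scatter. Against the 2-chloro-4-fluorophenyl group the same 4-hydroxy-3-methoxyphenyl gives a 4.3-fold higher number from compound 1 to compound 4 (0.64 log units; beyond the scatter) and this is the widest step in the series. Methoxy in place of fluoro on an aromatic carbon gives only a 1.9-fold higher number from compound 2 to compound 4 (0.28 log units; within the scatter) and leaves those two compounds unresolved. No measurement here accounts for these differences. On these data alone, how an amine or a carboxylic acid on this aryl ring would behave remains open.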